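A low-inhibition series and a carbamate replacement

This account rests on a few compounds, and the source may have more. Where it says the series, first, only, none or still open, it means among the compounds named here.

Compound 1 `CC(C)=CCC1Cc2c(OCCCNC(=O)c3ccco3)cc(=O)n(CCCO)c2CC1(C)C` gives 4.3% in a functional assay on PANC-1 cells (Homo sapiens) for inhibition, read by MTT assay, with a stated time of 24 h, tested at 10 uM (a higher number here means more inhibition at the concentration tested (going by the name of the read-out), a lower number less inhibition), which places it second highest of three numbers, with compound 3 nearest and compound 2 furthest, though every gap lies within the scatter. Compound 2 `CC(C)=CCC1Cc2c(OCCCNC(=O)c3ccc([N+](=O)[O-])cc3)cc(=O)n(CCCO)c2CC1(C)C` gives 9.1% in this assay, and compound 3 `COc1ccc(OCCCOc2cc(=O)n(CCCO)c3c2CC(CC=C(C)C)C(C)(C)C3)cc1` gives 4.1% in this assay.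

Compound 4 `CC(C)=CCC1Cc2c(OC(=O)Nc3ccccc3F)cc(=O)n(CCCO)c2CC1(C)C` has not been measured. It differs from compound 1 by (2-fluorophenyl)carbamoyl in place of 3-(((furan-2-yl)carbonyl)amino)propyl on an oxygen on an aromatic ring. The measured steps that start from compound 1 are a number 4.8 percentage points higher from compound 1 to compound 2 (within the scatter) and a number 0.2 percentage points lower from compound 1 to compound 3 (within the scatter), neither of which moved the number beyond the scatter, and neither of them touches the part that changes here, since both keep a three-carbon chain on the aromatic oxygen. Nothing in the three compounds shows a step in either direction, so no step beyond the scatter is expected.

Compound 4 is therefore estimated at 6%, between -5% and 18%, which means an expected step of a number 1.7 percentage points higher from compound 1 to compound 4 (within the scatter).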

Compound 4, a percentage reported as inhibition, at one concentration (the size of the read-out at that concentration, not a potency): 0%
For compound 4 the middle estimate is 6 percentage points above the measured one; the range from low to high includes it.
By their numbers in this assay, from the lowest: compounds 4, 3, 1 and 2 (each within the scatter of the next).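

In this assay the result is a number 4.3 percentage points lower from compound 1 to compound 4 (within the scatter), so the oxygen on the aromatic ring can lose the whole 3-(((furan-2-yl)carbonyl)amino)propyl group and take (2-fluorophenyl)carbamoyl without the number leaving the scatter. The earlier compounds shown here changed only what the chain carried, whereas this change replaces the chain itself, and even that leaves no readable effect, although compound 1 at 4.3% has little room for a drop to show. Nothing measured here explains why the number stays put.

On these data alone, what remains open is whether any group on this oxygen can lift the number beyond the scatter, for instance a longer chain ending in an amine or a carboxylic acid. The compounds shown also leave open whether the fluorine on the phenyl ring matters, since no carbamoyl without it appears beside compound 4.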